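The source may report more compounds than this note shows. Statements on the series, on what has been measured and on what is new or still open speak of the compounds shown alone.

Measured compounds, with their readings in a functional assay on KB cells (Homo sapiens) for antiproliferative activity, read by MTT assay, with a stated time of 48 h; a higher number here means a weaker inhibitor, a lower number a stronger inhibitor:

compound 1, `Cn1cc(C2=C(c3nn(CCCn4cncn4)c4ncccc34)C(=O)NC2=O)c2ccccc21`: > 100000 nM
compound 2, `Cn1cc(C2=C(c3nn(CCn4ccnc4)c4ncccc34)C(=O)N(c3ccccc3)C2=O)c2ccccc21`: > 100000 nM
compound 3, `Cn1cc(C2=C(c3nn(CCCN4CCCCC4)c4ncccc34)C(=O)N(c3ccc(Cl)cc3)C2=O)c2ccccc21`: > 100000 nM

All three readings are limits of this assay rather than numbers. Compound 1 reaches only the limit > 100000 nM in this assay. Compound 2 likewise stops at the limit > 100000 nM. Compound 3 also stops at the limit > 100000 nM. Among the compounds with values here, compound 1 therefore cannot be placed in any order against compound 2 or compound 3; what the series shows so far is summed up by the limit of > 100000 nM in this assay, at which 3 of the 3 values shown sit, and no step between measured compounds can be counted.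

The next compound is compound 4, `Cn1cc(C2=C(c3nn(CCCO)c4ncccc34)C(=O)NC2=O)c2ccccc21`. It differs from compound 1 in one place: hydroxy in place of 1H-1,2,4-triazol-1-yl on a saturated chain carbon, three bonds along the chain from an aromatic nitrogen. The shared core is kept, and the change sits on the 3-(1H-1,2,4-triazol-1-yl)propyl chain, which becomes 3-hydroxypropyl.

Within the data shown here, with no measured step and every reading at the limit, no direction can be drawn from the data for the step from compound 1 to compound 4. The expectation is that compound 4 will behave like compound 1, with the step of a number no higher from compound 1 to compound 4 (the limit leaves the size open) expected to amount to nothing beyond the scatter. For compound 4 the estimate in this assay is 100000 nM, with a range from 30000 nM to 300000 nM, and most likely only a limit will again be recorded.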

Compound 4, half-maximal inhibitory concentration: > 100000 nM
Compound 4: only a limit was reported; the forecaster's own chance of this, stated with the estimate: 80%; the middle value sits exactly at the limit.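

In this assay compound 4 gives > 100000 nM as a limit and not a number, and with compound 1 also at a limit, no step between the two can be read: the limit of > 100000 nM in this assay, at which 4 of the 4 values shown sit.

The compounds shown leave open whether hydroxy and 1H-1,2,4-triazol-1-yl on the chain differ at all in their effect on the reading.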